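Acetyl for Carbamoyl on Two Pyrimidine Cores

The source may hold more compounds than are shown below. What is called first, only, known or untested is meant among the compounds shown, and "the series" means these compounds.

The series comprises compound 1 `CC(=O)Nc1nccc(-c2ccncc2)n1`, compound 2 `NC(=O)Nc1nccc(-c2ccncc2)n1`, compound 3 `CC(C)(C)c1nc(NC(N)=O)ncc1-c1ccccc1` and the unmeasured compound 4 `CC(=O)Nc1ncc(-c2ccccc2)c(C(C)(C)C)n1`. In a functional assay on the whole organism for inhibition, with Rattus norvegicus as the target, with stated times of 1 h and 3.5 h, at a dose of 100 mg/kg by the oral route (a higher number here means more inhibition at the dose given (going by the name of the read-out), a lower number less inhibition), compound 1 gives 52%, compound 2 gives 12% and compound 3 gives 14%. Among the measured compounds shown here, compound 2 and compound 1 differ by methyl in place of amino on a carbonyl carbon, and this step, a number 40 percentage points higher from compound 2 to compound 1 (beyond the scatter), is the only measured instance of the change. Compound 3 carries the same change to reach compound 4, (methyl in place of amino on a carbonyl carbon), while the difference between the cores of compound 2 and compound 3 is not broken down here. Compound 3 and compound 2 lie within the scatter of each other in this assay. Because the earlier step was a number 40 percentage points higher from compound 2 to compound 1 (beyond the scatter), compound 4 is expected to rise by about a number 36 percentage points higher from compound 3 to compound 4 (beyond the scatter), giving an estimated 50%, between 25% and 75%.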

Compound 4, a percentage reported as inhibition, in the whole organism at one dose (the size of the read-out at that dose, not a potency): 29%
The estimate for compound 4 lay 21 percentage points above the measured number, within the range that was stated.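

In this assay, methyl in place of amino on a carbonyl carbon again goes with a higher number, a number 15 percentage points higher from compound 3 to compound 4 (beyond the scatter), so the direction of the change holds on the second core. Its size does not carry over from one core to the other: the same change on two cores in this assay, a number 40 percentage points higher (beyond the scatter) from compound 2 to compound 1 and a number 15 percentage points higher (beyond the scatter) from compound 3 to compound 4, 25 percentage points apart, beyond the scatter of two such steps. Among the compounds shown here, with only two cores, this shows neither how the size of the step depends on the core nor which part of the difference between the cores matters.

The compounds shown leave open how a longer chain such as propyl, or an amine such as dimethylamino, would compare with methyl on the same carbonyl carbon. They also leave open whether the step would hold on any further core.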